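Amide variants of a dimethoxy tetralin acetic acid

This account rests on a few compounds, and the source may have more. Where it says the series, first, only, none or still open, it means among the compounds named here.

Compound 1, `COc1cc2c(cc1OC)C(CC(=O)O)CC2`: 20.4%
Compound 2, `COc1cc2c(cc1OC)C(CC(N)=O)CC2`: 27.8%
Compound 3, `CCN(CC)C(=O)CC1CCc2cc(OC)c(OC)cc21`: 31.5%

In a functional assay on the whole organism (strain Wistar) for inhibition, with Rattus norvegicus as the target, read by paw edema, with stated times of 60 min and 6 h, at a dose of 100 mg/kg by the oral route (a higher number here means more inhibition at the dose given (going by the name of the read-out), a lower number less inhibition), compound 1 gives the lowest of the three numbers; compound 2 sits within the scatter of it, while compound 3 lies beyond it, as the step of a number 11.1 percentage points higher from compound 1 to compound 3 (beyond the scatter) shows. Compound 4, `CCCNC(=O)CC1CCc2cc(OC)c(OC)cc21`, is not yet measured. It differs from compound 1 as follows: propylamino in place of hydroxy on a carbonyl carbon. Going by the values given here, two measured steps bear on this change, both replacing the hydroxy on the carbonyl carbon by a nitrogen group: a number 7.4 percentage points higher from compound 1 to compound 2 (within the scatter) and a number 11.1 percentage points higher from compound 1 to compound 3 (beyond the scatter). Compound 4 carries a propylamino group, so an increase of similar size is expected, a number 8.6 percentage points higher from compound 1 to compound 4 (within the scatter). The estimate for compound 4 is 29%, in the range 17% to 41%.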

Compound 4, a percentage reported as inhibition, in the whole organism at one dose (the size of the read-out at that dose, not a potency): 22.2%
For compound 4 the middle estimate is 6.8 percentage points above the measured one, and the stated range covers the measured number.
By their numbers in this assay, from the lowest: compounds 1, 4, 2 and 3 (each within the scatter of the next, the first and the last beyond it).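

In this assay, propylamino on the carbonyl carbon cannot be separated from the hydroxy of the acid (a number 1.8 percentage points higher from compound 1 to compound 4 (within the scatter)). A nitrogen group at this place therefore does not by itself give a step beyond the scatter, and among the amides shown only diethylamino does so. Compound 4 also cannot be separated from the other two amides (a number 9.3 percentage points lower from compound 3 to compound 4 (within the scatter)) and (a number 5.6 percentage points lower from compound 2 to compound 4 (within the scatter)).

Open, from the compounds shown here alone, is whether a piperidine amide or a longer chain such as hexylamino on the same carbonyl carbon would stand clear of the acid. No supporting data at hand explain these numbers.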